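Swapping fluoro for methyl on a core with no measurable cytotoxicity

This account rests on a few compounds, and the source may have more. Where it says the series, first, only, none or still open, it means among the compounds named here.

In an ADME assay on CCRF-CEM cells (Homo sapiens) for cytotoxicity, with a stated time of 72 h (on this read-out higher numbers stand for weaker inhibition and lower numbers for stronger inhibition), compound 1 `Fc1ccc(-c2cn3nc(Cc4ccc(Cl)cc4)sc3n2)cc1` gives > 250000 nM, which is a limit of the assay rather than a measured number. Two further compounds share its core. Compound 2 `Clc1ccc(-c2cn3nc(Cl)sc3n2)cc1` gives > 250000 nM, again only a limit. Compound 3 `COc1ccc(-c2cn3nc(Cl)sc3n2)cc1` gives > 250000 nM, also a limit. The single one-point step among these compounds, a step that the two limits leave unreadable from compound 2 to compound 3, therefore cannot be read, since both of its ends sit at the limit. What the numbers do show is the limit of > 250000 nM in this assay, at which 3 of the 3 values shown sit, so no compound in this set has yet shown measurable cell killing in this assay.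

Compound 4 `Cc1ccc(-c2cn3nc(Cc4ccc(Cl)cc4)sc3n2)cc1` differs from compound 1 by methyl in place of fluoro on an aromatic carbon. Within the data shown here, no measured step touches a fluoro or a methyl group, and the only step that was measured, the exchange of chloro for methoxy, gave no readable size. With every value at the limit, there is no basis to expect this change to bring a number into view, and the most likely outcome is once more a limit. Compound 4 is therefore expected to give 350000 nM, with a range from 100000 nM to 1500000 nM. This estimate implies the step that the limit leaves unreadable from compound 1 to compound 4, which is expected to be none beyond the scatter.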

Compound 4, half-maximal inhibitory concentration: > 250000 nM
Compound 4: no number, only a limit; the forecaster's own chance of this, stated with the estimate: 85%; the middle value does not contradict the limit.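

Compound 1 and compound 4 both sit at a limit rather than a number, so the exchange of fluoro for methyl between them has no size that can be read. The picture stays as it was: the limit of > 250000 nM in this assay, at which 4 of the 4 values shown sit. Going by these compounds, what stays open is whether any compound on this shared core gives a real number in this assay at all.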